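Removing an Ethoxycarbonyl Group: Expectation for Compound 4

This account rests on a few compounds, and the source may have more. Where it says the series, first, only, none or still open, it means among the compounds named here.

Compound 1 `CSc1cnc2ccccc2c1[Se]CC#CCO`: 4.2 ug/mL
Compound 2 `CSc1cnc2ccccc2c1[Se]CC#CCCl`: 3.5 ug/mL
Compound 3 `CCOC(=O)OCC#CCSc1c(SC)cnc2ccccc12`: 5.5 ug/mL

These three compounds were measured in a functional assay on B16 cells (Mus musculus) for antiproliferative activity, with a stated time of 72 h; on this read-out lower numbers stand for stronger inhibition and higher numbers for weaker inhibition. Compound 3 gives the highest of the three numbers, but its gaps to compound 1 and compound 2 are both within the scatter, so the three stand together rather than in any order. For the measured compounds named here, the only step between measured compounds that differ in one place is a 1.2-fold lower number from compound 1 to compound 2 (0.08 log units; within the scatter), a chloro in place of hydroxy on a saturated chain carbon bound to a triple-bonded carbon.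

Compound 4 `CSc1cnc2ccccc2c1SCC#CCO` has not yet been measured in this assay. It differs from compound 3 by hydrogen in place of ethoxycarbonyl on an oxygen on a saturated carbon. Going by the values given here, no measured step concerns this kind of change; the step from compound 1 to compound 2 alters a different group on the chain and does not bear on it. With three values that all sit within the scatter of one another, and no guide for the change itself, no step beyond the scatter is expected. The estimate for compound 4 is therefore 5 ug/mL, with a range from 2.5 ug/mL to 10 ug/mL, which means an expected step of a 1.1-fold lower number from compound 3 to compound 4 (0.04 log units; within the scatter).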

Compound 4, concentration for 50% inhibition: 49.8 ug/mL
The estimate for compound 4 lay 10-fold (1.00 log units) below the measured number; the measured number lies above the stated range.
By their numbers in this assay, from the lowest: compounds 2, 1 and 3 (each within the scatter of the next); then compound 4.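

In this assay, the group on the oxygen matters when the chain is attached through sulfur: hydrogen in place of ethoxycarbonyl gives a 9.1-fold higher number from compound 3 to compound 4 (0.96 log units; beyond the scatter) and moves compound 4 clear of the three earlier compounds, which sit within the scatter of one another. A hydroxy end alone does not bring this high number, as the exchange of selenium for sulfur with that end unchanged gives a 12-fold higher number from compound 1 to compound 4 (1.07 log units; beyond the scatter) and shows that the atom joining the chain to the core counts too; a 14-fold higher number from compound 2 to compound 4 (1.15 log units; beyond the scatter) combines that same exchange with hydroxy in place of chloro, so it cannot separate the two changes. No measurement shown here gives a reason for these steps.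

As far as these compounds go, it remains open whether a chloro end on the sulfur-linked chain, or an acetyl or methyl group on the oxygen, would bring the number back down as ethoxycarbonyl does. From the compounds shown here alone, it is also open what ethoxycarbonyl would do on the selenium-linked chain, where compound 1 with its free hydroxy already gives 4.2 ug/mL in this assay and the two features may not simply add up.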